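Half-life notes on the series: compound 3 to compound 4

The source may report more compounds than this note shows. Statements on the series, on what has been measured and on what is new or still open speak of the compounds shown alone.

Measured in an in vivo ADME assay on the whole organism (Cavia porcellus); a lower number here means that the compound disappears faster, a higher number that the compound lasts longer
compound 1 (`CC(C)C(NC(=O)c1ccc(C(=N)N)cc1)C(C)(C)C(=O)N1CCC(CC(=O)O)CC1`) gives 0.8 h
compound 2 (`CCOC(=O)CC1CCN(C(=O)C(C)(C)C(CC)NC(=O)c2ccc(C(=N)N3CCCC3)cc2F)CC1`) gives 2.07 h
compound 3 (`CCOC(=O)CC1CCN(C(=O)C(C)(C)C(CC)NC(=O)c2ccc(C(=N)N3CCC(O)CC3)cc2F)CC1`) gives 3.5 h

Compound 3 (at 3.5 h) sits within the scatter of compound 2 (at 2.07 h). Compound 1 stands at 0.8 h. The gap from that number to compound 3 lies beyond the scatter, so compound 3 lasts longer than compound 1 and cannot be told apart from compound 2.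

The next structure is compound 4 (`CCOC(=O)CC1CCN(C(=O)C(C)(C)C(CC)NC(=O)c2ccc(C(=N)N3CCN(C)CC3)cc2F)CC1`), with 4-methylpiperazin-1-yl in place of 4-hydroxypiperidin-1-yl on a carbon with a double bond to nitrogen.

Going by the values given here, one measured step bears on this change: a 1.7-fold higher number from compound 2 to compound 3 (0.23 log units; within the scatter), which brought in 4-hydroxypiperidin-1-yl in place of pyrrolidin-1-yl at the same place. That step stays within the scatter, and no direction can be read from it. Compound 1 differs from compound 3 in more than one place and offers no clean comparison. Among the compounds with values here, no measured compound carries 4-methylpiperazin-1-yl.

Resting on that single step, the expected change in this assay is a 1.3-fold lower number from compound 3 to compound 4 (0.10 log units; within the scatter) and no shift beyond the scatter is expected. For compound 4 the estimated half-life is 2.8 h, with an expected range from 1.4 h to 5.5 h.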

Compound 4, half-life: 1.77 h
Compound 4: the middle estimate sits 1.6-fold (0.20 log units) above what was measured; the measured number falls inside the stated range.
By their numbers in this assay, from the lowest: compound 1; then compounds 4, 2 and 3 (each within the scatter of the next).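

In this assay, 4-methylpiperazin-1-yl in place of 4-hydroxypiperidin-1-yl on a carbon with a double bond to nitrogen gives a 2.0-fold lower number from compound 3 to compound 4 (0.30 log units; within the scatter), so the swap from a group with one hydrogen-bond donor to a group with none does not carry the half-life beyond the scatter. Set against pyrrolidin-1-yl at the same place, 4-methylpiperazin-1-yl gives a 1.2-fold lower number from compound 2 to compound 4 (0.07 log units; within the scatter), which means that compounds 2, 3 and 4 all lie within the scatter of one another and these three groups cannot be told apart by this read-out. No supporting data are available to explain these numbers.

From the compounds shown here alone, whether a morpholin-4-yl ring or an open-chain dimethylamino group at this place would also stay within that scatter remains open. Compound 1 differs from compounds 2, 3 and 4 in more than one place, so the compounds shown do not tell which of its parts goes with its separation from compound 3, and the effect of a carboxylic acid in place of the ethyl ester alone remains unresolved.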